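The source may hold more compounds than are shown below. What is called first, only, known or untested is meant among the compounds shown, and "the series" means these compounds.

The growth read-out in question is a functional assay on UACC-62 cells (Homo sapiens) for inhibition, read by sulforhodamine B assay, with a stated time of 48 h; on this read-out lower numbers stand for stronger inhibition of growth and higher numbers for weaker inhibition of growth. Measured compounds and their values:

compound 1 `O=C(Nc1cccc(-n2cc(-c3ccncc3)c(-c3ccc(Cl)c(O)c3)n2)c1)Nc1cccc(C(F)(F)F)c1` gives 6910 nM
compound 2 `O=C(Nc1cccc(-n2cc(-c3ccncc3)c(-c3ccc(Cl)c(O)c3)n2)c1)Nc1ccc(Cl)c(Cl)c1` gives 5210 nM
compound 3 `COc1cc(-c2nn(-c3cccc(NC(=O)c4ccc(Cl)c(C(F)(F)F)c4)c3)cc2-c2ccncc2)ccc1Cl` gives > 32500 nM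

Compound 1 stands highest of the two numbers in this assay; its nearest neighbour is compound 2, and the step of a 1.3-fold lower number from compound 1 to compound 2 (0.12 log units; within the scatter) shows that swapping the aryl group on the amide-type nitrogen left the result within the scatter. The value given for compound 3 is a limit of the assay, not a number (the limit of > 32500 nM in this assay, at which 1 of the 3 values shown sits).

Compound 4 `O=C(Nc1cccc(-n2cc(-c3ccncc3)c(-c3ccc(Cl)c(O)c3)n2)c1)Nc1cc(C(F)(F)F)cc(C(F)(F)F)c1` differs from compound 1 by a single change: trifluoromethyl in place of hydrogen on an aromatic carbon, so that the ring on the amide-type nitrogen now carries two trifluoromethyl groups. Going by the values given here, no measured step adds a group to this ring; the only step at this position, from compound 1 to compound 2, stayed within the scatter. Accordingly no shift beyond the scatter is expected in this assay for compound 4, and the estimated step is a 1.0-fold higher number from compound 1 to compound 4 (0.01 log units; within the scatter). Compound 4 is therefore expected to give about 7000 nM, with a likely range from 3000 nM to 16000 nM.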

Compound 4, concentration for total growth inhibition: 2190 nM
The estimate for compound 4 lay 3.2-fold (0.50 log units) above the measured number; the measured number lies below the stated range.
By their numbers in this assay, from the lowest: compound 4; then compounds 2 and 1 (each within the scatter of the next). At a limit, above all of these: compound 3.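

In this assay, this ring on the amide-type nitrogen now shows that a change there can move the number beyond the scatter: adding a trifluoromethyl group gives a 3.2-fold lower number from compound 1 to compound 4 (0.50 log units; beyond the scatter). The earlier change at this ring gave only a 1.3-fold lower number from compound 1 to compound 2 (0.12 log units; within the scatter), so exchanging 3-(trifluoromethyl)phenyl for 3,4-dichlorophenyl showed no clear shift, whereas adding this group, meta to a trifluoromethyl group, does. Nothing in the information available explains why this addition lowers the number.

With a single addition of this kind among the compounds shown, it remains open whether the shift is particular to trifluoromethyl. An amine or a carboxylic acid on the same aromatic carbon could show whether other groups there move the number in the same direction, in the opposite direction or not at all.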